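Nitro for Methyl on the Benzyl Arm of Compound 1

The source may report more compounds than this note shows. Statements on the series, on what has been measured and on what is new or still open speak of the compounds shown alone.

Compound 1, with the structure `CSCC[C@H](NC(=O)c1ccc(NCc2cncn2Cc2ccccc2C)cc1-c1ccccc1)C(=O)O`, was tested in a functional assay on NIH3T3 cells (Mus musculus); on this read-out lower numbers stand for an effect already at smaller amounts and higher numbers for an effect only at larger amounts of compound. In this assay compound 1 gives > 10 uM, which is a limit of the assay rather than a measured number. Two related compounds share this outcome. Compound 2, `COC(=O)[C@H](CCSC)NC(=O)c1ccc(CN(Cc2c[nH]cn2)Cc2c[nH]cn2)cc1-c1ccccc1C`, gives > 10 uM in this assay, again a limit. Compound 3, `COC(=O)[C@H](CCSC)NC(=O)c1ccc(NCc2cncn2Cc2ccc(Cl)cc2)cc1-c1ccccc1`, gives > 10 uM in this assay, also a limit. For the measured compounds named here, since no compound reached a measurable number, there is no step between measured compounds to compare; the only evidence is the limit of > 10 uM in this assay, at which 3 of the 3 values shown sit.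

The next compound, compound 4, has the structure `CSCC[C@H](NC(=O)c1ccc(NCc2cncn2Cc2ccc([N+](=O)[O-])cc2)cc1-c1ccccc1)C(=O)O`. It differs from compound 1 in one place: 4-nitrophenyl in place of 2-methylphenyl on a saturated chain carbon bound to an aromatic nitrogen. Going by the values given here, nothing among the measured compounds shows what a 4-nitrophenyl in this position does, so the expectation rests only on the fact that every tested compound sat at the limit.

The step from compound 1 to compound 4 is therefore expected to be small, a step that the limit leaves unreadable from compound 1 to compound 4, with no clear direction beyond the scatter. Compound 4 is expected to give about 15 uM in this assay, most likely between 4 uM and 60 uM, and quite possibly only a limit once more.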

Compound 4, concentration for half-maximal effect: > 10 uM
Compound 4: only a limit was reported; the forecaster's own chance of this, stated with the estimate: 70%; the middle value is on the limit's open side.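

In this assay compound 4 gives > 10 uM, which is a limit of the assay and not a number. Compound 1 also stands at a limit, so the step from compound 1 to compound 4 cannot be read. The compounds shown leave open whether 4-nitrobenzyl and 2-methylbenzyl differ at all, and what would bring a measurable number in this assay.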